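Moving the methoxy group on the ester aryl ring

The source may hold more compounds than are shown below. What is called first, only, known or untested is meant among the compounds shown, and "the series" means these compounds.

Measured compounds:
compound 1 `CC1=CC[C@H](C(C)C)c2cc(C)c(OC(=O)c3ccc(C)cc3)cc21` gives 85.4%
compound 2 `Cc1cc2c(C(C)C)ccc(C)c2cc1OC(=O)c1cccc(C(F)(F)F)c1` gives 17.3%
compound 3 `COc1cccc(C(=O)Oc2cc3c(C)ccc(C(C)C)c3cc2C)c1` gives 30.6%

In a functional assay on SK-LU-1 cells (Homo sapiens) for antiproliferative activity, read by sulforhodamine B assay, with a stated time of 48 h, tested at 50 uM (on this read-out lower numbers stand for less inhibition and higher numbers for more inhibition at the one concentration tested (going by the name of the read-out)), compound 1 reaches 85.4%, while compound 2 gives 17.3% and compound 3 gives 30.6%. Compound 3 thus stands second highest of the three numbers in this assay: nearest to it is compound 2, a number beyond the scatter lower, and furthest is compound 1, a number beyond the scatter higher. Among the measured compounds shown here, the one step that can be computed, a number 13.3 percentage points higher from compound 2 to compound 3 (beyond the scatter), concerns a change of the group on the aromatic carbon, not a change of where a methoxy group sits.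

Compound 4 `COc1ccc(C(=O)Oc2cc3c(C)ccc(C(C)C)c3cc2C)cc1` is the next compound, and it differs from compound 3 only in this way: 4-methoxyphenyl in place of 3-methoxyphenyl on a carbonyl carbon. For the measured compounds named here, no measured step moves a methoxy group from one place on the ester aryl ring to another, so nothing among the measured compounds bears directly on this change. The step from compound 2 to compound 3 shows only that the ester aryl substituent matters, and it is modest in size.

Compound 4 is therefore expected to stay close to compound 3, with an estimated step of a number 2.4 percentage points higher from compound 3 to compound 4 (within the scatter) in this assay that does not go beyond the scatter. The estimate for compound 4 is 33%, in a range from 14% to 56%.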

Compound 4, a percentage reported as inhibition, at one concentration (the size of the read-out at that concentration, not a potency): 32.8%
Beside the measured number, compound 4's estimate is 0.2 percentage points above it, within the range that was stated.
By their numbers in this assay, from the lowest: compound 2; then compounds 3 and 4 (each within the scatter of the next); then compound 1.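

In this assay the exchange of 3-methoxyphenyl for 4-methoxyphenyl on a carbonyl carbon gives a number 2.2 percentage points higher from compound 3 to compound 4 (within the scatter) at the one concentration tested, so the two methoxy placements cannot be told apart on this read-out. Among the compounds shown here, the earlier finding of a number 13.3 percentage points higher from compound 2 to compound 3 (beyond the scatter) came from putting one group in place of another on the ester aryl ring, and it showed only that the choice of group can move the number beyond the scatter. This new pair adds that relocating the same methoxy group, with the atoms unchanged, yields no difference beyond the scatter in this pair of compounds. Nothing at hand offers an explanation for this outcome.

Going by these compounds, whether an amine, a carboxylic acid or a longer alkoxy chain on the ester aryl ring would change the number in the same assay remains open, as does whether any such group would behave alike at both placements. The single-concentration read-out also leaves open whether compound 3 and compound 4 would remain indistinguishable at other concentrations, since no potency is given for either.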